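The source may report more compounds than this note shows. Statements on the series, on what has been measured and on what is new or still open speak of the compounds shown alone.

Compounds measured in an assay on HEK293 cells for inhibition of solute carrier family 12 member 2 (Homo sapiens), read by fluorescence, with a stated time of 30 min, tested at 100 uM; a higher number here means a stronger effect of the compound at the concentration tested, a lower number a weaker effect:
compound 1, `CCCCNc1ccc([N+](=O)[O-])cc1S(N)(=O)=O`: 4.7%
compound 2, `CCCCNc1ccc([N+](=O)[O-])cc1S(=O)(=O)NC`: 13.3%

Compound 1 gives the lowest of the two numbers in this assay; the nearest is compound 2, and the step of a number 8.6 percentage points higher from compound 1 to compound 2 (within the scatter) lies within the scatter, so the two cannot be ordered. Among the compounds with values here, compound 3, `CCCCNc1ccc(C(=O)O)cc1S(N)(=O)=O`, has not yet been measured. carboxy in place of nitro on an aromatic carbon No measured step bears on this change; the only step known alters the sulfonamide nitrogen, not the aromatic carbon, and so offers no guide. Compound 3 is therefore expected to stay near compound 1, with a step of a number 3.3 percentage points higher from compound 1 to compound 3 (within the scatter) that remains within the scatter. The estimate for compound 3 is 8%, with a range from 0% to 25%.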

Compound 3, a percentage reported as inhibition, at one concentration (the size of the read-out at that concentration, not a potency): 6.4%
The estimate for compound 3 lay 1.6 percentage points above the measured number, within the range that was stated.
By their numbers in this assay, from the lowest: compounds 1, 3 and 2 (each within the scatter of the next).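

In this assay carboxy in place of nitro, on the aromatic carbon para to a butylamino group and meta to a sulfamoyl group, gives a number 1.7 percentage points higher from compound 1 to compound 3 (within the scatter) and so the two compounds cannot be ordered. This is the only step shown at this position, and at the concentration tested it does not tell nitro and carboxy apart. Nothing measured here accounts for the result.

Going by these compounds, whether an amine, a nitrile or a plain hydrogen at this position would read differently stays open. So does the effect of a longer chain in place of the butyl chain.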